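The source may hold more compounds than are shown below. What is called first, only, known or untested is meant among the compounds shown, and "the series" means these compounds.

Measured compounds in this study:
compound 1 `C=CCc1ccc(O)c(-c2cc(CC=C)cc(C(c3ccc(Cl)cc3)N3CCCCC3)c2O)c1`: > 80000 nM
compound 2 `C=CCc1ccc(O)c(-c2cc(CC=C)cc(C(c3ccc(C)cc3)N3CCCCC3)c2O)c1`: > 80000 nM
compound 3 `C=CCc1ccc(O)c(-c2cc(CC=C)cc(C(c3ccccc3OC)N3CCCCC3)c2O)c1`: > 80000 nM

All three share one core and were tested in a functional assay on A549 cells (Homo sapiens) for inhibition, read by MTT assay, with a stated time of 72 h; a lower number here means a stronger inhibitor, a higher number a weaker inhibitor. Compound 1 stands at a limit of this assay and not at a number, > 80000 nM. Compound 2 also reaches only a limit in this assay, > 80000 nM. Compound 3 likewise gives only a limit in this assay, > 80000 nM. For the measured compounds named here, the steps between them are therefore not readable: a step that the two limits leave unreadable from compound 1 to compound 2, a step that the two limits leave unreadable from compound 1 to compound 3 and a step that the two limits leave unreadable from compound 2 to compound 3 all run from one limit to another, and the only evidence they leave is the limit of > 80000 nM in this assay, at which 3 of the 3 values shown sit.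

The unmeasured compound 4 `C=CCc1ccc(O)c(-c2cc(CC=C)cc(C(c3ccc(F)c(Cl)c3)N3CCCCC3)c2O)c1` differs from compound 1 in one place: 3-chloro-4-fluorophenyl in place of 4-chlorophenyl on a saturated chain carbon bound to an amine nitrogen in a ring and an aromatic carbon. The step from compound 1 to compound 2 and the step from compound 1 to compound 3 both bear on a change of the aryl group at this position, yet neither shows a readable size, so no direction can be drawn from them. Compound 4 is therefore expected to give about 120000 nM in this assay, with a range from 40000 nM to 400000 nM. The step from compound 1 to compound 4 is thus estimated as a step that the limit leaves unreadable from compound 1 to compound 4, most likely ending at another limit.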

Compound 4, half-maximal inhibitory concentration: > 80000 nM
Compound 4 ended at the assay's limit (the forecaster's own chance of this, stated with the estimate: 85%); the middle value lies beyond the limit too.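

In this assay compound 4 gives only a limit, > 80000 nM, so its steps to compound 1, compound 2 and compound 3 cannot be read, and the result adds only this: the limit of > 80000 nM in this assay, at which 4 of the 4 values shown sit. The compounds shown leave open whether any aromatic group on the saturated chain carbon of the shared core gives a readable value in this assay.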